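A Larger Aromatic Group on the Amine Nitrogen

A few compounds are considered here, and "the series" means these few. Any claim that something is new, unique, unknown or untested is made for them only; others in the source may bear on it.

Three close relatives have been measured in a physicochemical assay for lipophilicity; a lower number here means a more polar compound, a higher number a more lipophilic compound: compound 1 (`C=C(c1cccc2ccccc12)C1CCC2(CC1)COC(Nc1ccc(Cl)cc1)OO2`), compound 2 (`C=C(c1cccc2ccccc12)C1CCC2(CC1)COC(Nc1ccc(C)cc1)OO2`) and compound 3 (`C=C(c1ccc2ccccc2c1)C1CCC2(CC1)COC(Nc1ccc(Cl)cc1)OO2`). Compound 1 gives 6.15, compound 2 gives 6.08 and compound 3 gives 6.15. Compound 3 is therefore level with compound 1, and compound 2 lies within the scatter of both.

Compound 4 (`C=C(c1ccc2ccccc2c1)C1CCC2(CC1)COC(Nc1ccccc1-c1ccccc1)OO2`) is still unmeasured. It has 2-phenylphenyl in place of 4-chlorophenyl on an amine nitrogen.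

Two measured steps offer only limited guidance. One is a number 0.07 log units lower from compound 1 to compound 2 (within the scatter), a swap of methyl for chloro. The other is no change at the digits printed from compound 1 to compound 3 (within the scatter), a swap of naphthalen-2-yl for naphthalen-1-yl. Neither adds an aromatic ring, so their small size says little about this larger change. The entering group has more carbon atoms and a further ring, so a rise in this assay is expected, though its size is uncertain. The expected change is a number 0.75 log units higher from compound 3 to compound 4 (beyond the scatter). For compound 4 the estimated value is 6.9, with an expected range of 6.3 to 7.5.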

Compound 4, partition coefficient: 7.26
Compound 4: the middle estimate sits 0.36 log units below what was measured; the range from low to high includes it.
By their numbers in this assay, from the lowest: compounds 2, 1 and 3 (each within the scatter of the next); then compound 4.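

In this assay, 2-phenylphenyl in place of 4-chlorophenyl on an amine nitrogen gives a number 1.11 log units higher from compound 3 to compound 4 (beyond the scatter). This is the only step among these four compounds that lies beyond the scatter, showing that the group on this nitrogen can move the number substantially, even though swapping methyl for chloro on that same group gave only a number 0.07 log units lower from compound 1 to compound 2 (within the scatter). No measurement shown here accounts for the size of the rise.

This single step removes the chlorine and adds a second aromatic ring together, and the compounds shown cannot separate the contribution of either change. Going by these compounds, it also remains open how a plain phenyl or a cyclohexyl group on the same nitrogen would read, and whether a carboxylic acid on the entering group would bring the number back down.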